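The compounds below may be only part of what the source reports. "The series", "measured", "known", "first", "only" and "open" are said of these compounds alone.

In an assay on cells for inhibition of HSP60/HSP10 (Homo sapiens), with a stated time of 60 min (a higher number here means a weaker inhibitor, a lower number a stronger inhibitor), compound 2 `Cc1ccccc1S(=O)(=O)Nc1ccc(-c2nc3ccccc3o2)cc1` gives 85000 nM. Its number is the highest of the three measured, though nothing separates it from its neighbours: compound 3 `O=S(=O)(Nc1ccc(-c2nc3cc(NS(=O)(=O)c4ccccc4)ccc3o2)cc1)c1ccccc1` gives 80000 nM, and compound 1 `O=S(=O)(Nc1ccc(-c2nc3ccccc3o2)cc1)c1ccccc1C(F)(F)F` gives 74000 nM, both within the scatter of compound 2. Among the compounds with values here, the one measured step that changes a single group, a 1.1-fold higher number from compound 1 to compound 2 (0.06 log units; within the scatter), also concerns the phenyl on the sulfonyl sulfur and lies within the scatter.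

Compound 4 `O=S(=O)(Nc1ccc(-c2nc3ccccc3o2)cc1)c1ccc(Cl)cc1` is reached from compound 2 by a change at the same place: 4-chlorophenyl in place of 2-methylphenyl on a sulfonyl sulfur. The step from compound 1 to compound 2 is the only one that bears on it, since it too alters the substituent on that phenyl, and it was small. Within the data shown here, no measured compound carries 4-chlorophenyl on the sulfonyl sulfur, so the data give no direct guide to this group. On this basis compound 4 is expected to show no step beyond the scatter, the estimated change being a 1.1-fold lower number from compound 2 to compound 4 (0.03 log units; within the scatter). For compound 4 the estimate in this assay is 80000 nM, with a range from 35000 nM to 180000 nM.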

Compound 4, half-maximal inhibitory concentration: 61000 nM
Compound 4: the middle estimate sits 1.3-fold (0.12 log units) above what was measured; the range from low to high includes it.
By their numbers in this assay, from the lowest: compounds 4, 1, 3 and 2 (each within the scatter of the next).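

In this assay, the change to 4-chlorophenyl on a sulfonyl sulfur gives a 1.4-fold lower number from compound 2 to compound 4 (0.14 log units; within the scatter), so this step also stays within the scatter. Within the data shown here, the earlier step exchanged only one group on the phenyl while keeping 2-substitution; this one replaces 2-methylphenyl with 4-chlorophenyl, so both the substituent and its numbered place differ, and still no step beyond the scatter appears. The data offered here give no explanation for this result.

Every compound shown carries a phenyl ring on the sulfonyl sulfur, so it remains open whether an amine or a carboxylic acid on that phenyl, or a longer chain in its place, would produce a step beyond the scatter. As far as these compounds go, it is also open whether a change elsewhere in the shared core would do so.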